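Pyridin-2-yl in place of pyridin-3-yl

This account rests on a few compounds, and the source may have more. Where it says the series, first, only, none or still open, it means among the compounds named here.

Going by the values given here, in a functional assay on A549 cells (Homo sapiens) for antiproliferative activity, read by MTT assay, with a stated time of 72 h, in the presence of a further agent that is not named here (a higher number here means a weaker inhibitor, a lower number a stronger inhibitor), two compounds have values so far. Compound 1 `Nc1nc2[nH]c(CCSCC(=O)N[C@@H](CCC(=O)O)C(=O)O)cc2c(=O)[nH]1` gives 668 nM, and compound 2 `Nc1nc2[nH]c(CCSCC(=O)NCc3cccnc3)cc2c(=O)[nH]1` gives 56600 nM, the higher of the two numbers and so the weaker inhibitor of the pair. Among the compounds with values here, the only measured step, an 85-fold higher number from compound 1 to compound 2 (1.93 log units; beyond the scatter), is large and beyond the scatter. It places (pyridin-3-yl)methyl on the amide-type nitrogen in place of 1,3-dicarboxypropyl.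

The unmeasured compound 3 `Nc1nc2[nH]c(CCSCC(=O)NCc3ccccn3)cc2c(=O)[nH]1` differs from compound 2 as follows: pyridin-2-yl in place of pyridin-3-yl on a saturated chain carbon bound to an amide-type nitrogen. The two have the same atoms, joined differently. The measured step bears on this change only loosely, as it exchanges a whole substituent, whereas here one pyridine-bearing group replaces its isomer. Within the data shown here, no measured pair compares such isomers, so no step beyond the scatter is expected in this assay, and no direction is favoured. The estimated step is a 1.1-fold lower number from compound 2 to compound 3 (0.05 log units; within the scatter). For compound 3 the expected value is 50000 nM, with an estimated range of 17000 nM to 130000 nM.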

Compound 3, half-maximal inhibitory concentration: 14100 nM
Compound 3: the middle estimate sits 3.5-fold (0.55 log units) above what was measured, and the stated range ends above it.
By their numbers in this assay, from the lowest: compound 1; then compound 3; then compound 2.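

In this assay, pyridin-2-yl in place of pyridin-3-yl on a saturated chain carbon bound to an amide-type nitrogen gives a 4.0-fold lower number from compound 2 to compound 3 (0.60 log units; beyond the scatter) as a modest step, so this position separates two isomeric groups that have the same atoms and the same counts of donors and acceptors. The change does not close the gap to the 1,3-dicarboxypropyl group, since the comparison with the better isomer still gives a 21-fold higher number from compound 1 to compound 3 (1.32 log units; beyond the scatter) as a large step, and compound 1 stays lowest of the three in this assay. Nothing available here accounts for the difference between the two pyridine isomers or for the gap to compound 1.

Still open, as far as these compounds go, is how pyridin-4-yl would read at this position, and whether a longer chain between the amide-type nitrogen and the pyridine ring would keep the order of the two isomers. Also open, from the compounds shown here alone, is whether a simple carboxymethyl group on the amide-type nitrogen would bring the number back towards that of compound 1.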